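The compounds below may be only part of what the source reports. "The series", "measured", "known", "first", "only" and "open" are said of these compounds alone.

In a functional assay on KYSE-410 cells (Homo sapiens) for antiproliferative activity, read by MTT assay, with a stated time of 72 h (on this read-out lower numbers stand for stronger inhibition and higher numbers for weaker inhibition), compound 1 `O=C(Nc1ccccn1)c1cc(=O)[nH]c2cc(Br)ccc12` gives 9800 nM. Compound 2 `CC(C)(C)c1ccc(-c2ccc3c(C(=O)Nc4cccc(F)c4)cc(=O)[nH]c3c2)cc1` stands at > 20000 nM, which is a limit of the assay and not a number. Compound 3 `COc1ccc(-c2ccc3c(C(=O)Nc4cccc(F)c4)cc(=O)[nH]c3c2)cc1` differs from compound 2 at one place, with methoxy in place of tert-butyl on an aromatic carbon, para to a large group: methoxy in place of tert-butyl on an aromatic carbon. Among the measured compounds shown here, no measured pair of compounds shows what such a change does in this assay. A modest move toward stronger inhibition is expected, and the estimated step is an at least 1.6-fold lower number from compound 2 to compound 3 (0.22 log units; that floor lies within the scatter). For compound 3 the estimated value is 12000 nM, with an expected range of 5000 nM to 20000 nM.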

Compound 3, half-maximal inhibitory concentration: 18000 nM
The estimate for compound 3 lay 1.5-fold (0.18 log units) below the measured number; low and high end bracket the measured number.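

Methoxy in place of tert-butyl on an aromatic carbon, para to a large group, gives the only step shown at this position, an at least 1.1-fold lower number from compound 2 to compound 3 (0.04 log units; that floor lies within the scatter). Compound 2 stands at a limit of the assay and not a number: the limit of > 20000 nM in this assay, at which 1 of the 3 values shown sits. The step is thus only a floor. Among the compounds shown here, the one number at this position in this assay is that of compound 3, 18000 nM.

On these data alone, whether an amine or a carboxylic acid on that aromatic carbon would give a lower or higher number stays open. So does the effect of a longer chain there.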